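Methyl in Place of Hydrogen on the Chain Amine

This account rests on a few compounds, and the source may have more. Where it says the series, first, only, none or still open, it means among the compounds named here.

Two compounds of the series carry a measurement. Compound 1 `CNCCCNc1c(C(=O)NCc2ccc(F)cc2)nc(Br)c2cccnc12` and compound 2 `O=CNCCCCCCNc1nc(C(=O)NCc2ccc(F)cc2)c(O)c2ncccc12` were both tested in a functional assay on MDA-MB-435 cells (Homo sapiens) for cytotoxicity, read by MTT assay, with a stated time of 72 h; on this read-out higher numbers stand for weaker inhibition and lower numbers for stronger inhibition. In this assay compound 1 gives 11000 nM, and compound 2 gives 16000 nM. Going by the values given here, the two numbers lie within the usual scatter of each other, so compound 1 stands together with compound 2 rather than apart from it, and no step between measured compounds can be drawn from the pair.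

The next compound, compound 3 `CN(C)CCCNc1c(C(=O)NCc2ccc(F)cc2)nc(Br)c2cccnc12`, differs from compound 1 in one place: methyl in place of hydrogen on an amine nitrogen. The amine at the end of the chain is thus changed from methylamino to dimethylamino, while the shared core, the bromo substituent and the 4-fluorobenzyl amide are kept.

Among the compounds with values here, no measured step of this kind exists, so the expectation rests on the small size of the change alone. The step of no change at the digits printed from compound 1 to compound 3 (within the scatter) is expected to stay within the scatter, with no direction favoured. For compound 3 the estimated value in this assay is 11000 nM, with a range from 4500 nM to 27000 nM.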

Compound 3, half-maximal inhibitory concentration: 7000 nM
For compound 3 the middle estimate is 1.6-fold (0.20 log units) above the measured one; the range from low to high includes it.
By their numbers in this assay, from the lowest: compounds 3, 1 and 2 (each within the scatter of the next, the first and the last beyond it).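

Going by these compounds alone, the first single-place step is now available in this assay: methyl in place of hydrogen on an amine nitrogen gives a 1.6-fold lower number from compound 1 to compound 3 (0.20 log units; within the scatter). The earlier pair could not show this, since compound 1 and compound 2 differ in more than one place, whereas here the shared core, the bromo substituent and the 4-fluorobenzyl amide are held constant and only the end of the chain changes. At this position, methylamino and dimethylamino therefore cannot be told apart in this read-out, and the added methyl produces no step beyond the scatter, while no measurement at hand bears on the reason for this result.

From the compounds shown here alone, a single methyl step says little about how much room the amine nitrogen offers, so it remains open whether a primary amine, a diethylamino group or a piperidine ring at the end of the chain would keep the number in the same range. Also open, going by these compounds, is whether a longer chain carrying the same dimethylamino group would move the number beyond the scatter.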